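The compounds below may be only part of what the source reports. "The series", "measured", "known", "first", "only" and "open" are said of these compounds alone.

In an assay on isolated protein for inhibition of Amine oxidase [flavin-containing] B (Homo sapiens), read by fluorescence and Amplex Red, with a stated time of 30 min, tested at 100 uM (on this read-out higher numbers stand for a stronger effect at the one concentration tested and lower numbers for a weaker effect), the three measured compounds are: compound 1 `CCCCNc1nnc(SCC(=O)N(Cc2cccc([N+](=O)[O-])c2)c2ccc(F)cc2)s1` with 34.3%; compound 2 `CC(C)CNc1nnc(SCC(=O)N(Cc2cccc([N+](=O)[O-])c2)c2ccc(F)cc2)s1` with 24.2%; compound 3 `C=CCNc1nnc(SCC(=O)N(Cc2cccc([N+](=O)[O-])c2)c2ccc(F)cc2)s1` with 29.2%.

Compound 2 stands lowest of the three, yet only its gap to compound 1 lies beyond the scatter, while compound 3 sits within the scatter of it. Compound 4 `CC(C)Nc1nnc(SCC(=O)N(Cc2cccc([N+](=O)[O-])c2)c2ccc(F)cc2)s1` differs from compound 2 in one place: isopropyl in place of isobutyl on a nitrogen on an aromatic ring. Going by the values given here, the steps that bear on this all reshape the same chain on the aromatic nitrogen. Among the compounds with values here, the one step beyond the scatter was a number 10.1 percentage points lower from compound 1 to compound 2 (beyond the scatter); the others, a number 5.1 percentage points lower from compound 1 to compound 3 (within the scatter) and a number 5 percentage points higher from compound 2 to compound 3 (within the scatter), stayed within it. Removing one carbon from the branched chain is therefore expected to give at most a small rise, a number 5.8 percentage points higher from compound 2 to compound 4 (within the scatter), possibly none beyond the scatter. Compound 4 is estimated at 30%, within 18% to 42%.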

Compound 4, a percentage reported as inhibition, at one concentration (the size of the read-out at that concentration, not a potency): 28.5%
Beside the measured number, compound 4's estimate is 1.5 percentage points above it; measured number inside the range.
By their numbers in this assay, from the lowest: compounds 2, 4, 3 and 1 (each within the scatter of the next, the first and the last beyond it).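

Trimming isobutyl to isopropyl on this nitrogen gives a number 4.3 percentage points higher from compound 2 to compound 4 (within the scatter) and so brings no clear change in effect. Compound 4 also cannot be told apart from the allyl or butyl compounds, with a number 0.7 percentage points lower from compound 3 to compound 4 (within the scatter) and a number 5.8 percentage points lower from compound 1 to compound 4 (within the scatter) as the steps that show it. Butyl and isobutyl remain the only chains here that differ beyond the scatter, and isopropyl falls within the scatter of both. Still open, from the compounds shown here alone, is whether a cyclopropyl ring, or a chain carrying an amine or a carboxylic acid, on this nitrogen would shift the effect more clearly. No measurement shown here accounts for these small differences.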